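Side chain on the aromatic nitrogen: compound 3 to compound 4

The source may hold more compounds than are shown below. What is called first, only, known or untested is meant among the compounds shown, and "the series" means these compounds.

Measured in a functional assay (trachea) with Cavia porcellus as the target; a lower number here means a stronger inhibitor, a higher number a weaker inhibitor:
compound 1 `CC(C)n1nc(-c2cccnc2)c2ccccc2c1=O`: 3090 nM
compound 2 `CCCCCCCCn1nc(-c2cccnc2)c2ccccc2c1=O`: 21900 nM
compound 3 `COCCn1nc(-c2cccnc2)c2ccccc2c1=O`: 9330 nM

Compound 3 stands between compound 1 and compound 2, with a 3.0-fold higher number from compound 1 to compound 3 (0.48 log units; beyond the scatter) and a 2.3-fold lower number from compound 2 to compound 3 (0.37 log units; beyond the scatter). Next comes compound 4 `CCOC(=O)Cn1nc(-c2cccnc2)c2ccccc2c1=O`, with ethoxycarbonyl in place of methoxymethyl on a saturated chain carbon bound to an aromatic nitrogen. Within the data shown here, no measured step makes this exact change. The closest evidence is the other side-chain swaps, of which the largest is a 7.1-fold higher number from compound 1 to compound 2 (0.85 log units; beyond the scatter), and all three are modest. The data favour no direction, so no step beyond the scatter is expected in this assay. The expected step is a 1.0-fold lower number from compound 3 to compound 4 (0.02 log units; within the scatter). Compound 4 is estimated at 9000 nM, with an expected range of 3500 nM to 23000 nM.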

Compound 4, half-maximal inhibitory concentration: 43700 nM
Beside the measured number, compound 4's estimate is 4.9-fold (0.69 log units) below it, and the stated range ends below it.
By their numbers in this assay, from the lowest: compound 1; then compound 3; then compounds 2 and 4 (each within the scatter of the next).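

In this assay, the side chain on the aromatic nitrogen responds to this change: ethoxycarbonyl in place of methoxymethyl gives a 4.7-fold higher number from compound 3 to compound 4 (0.67 log units; beyond the scatter), and against the isopropyl side chain the gap is a 14-fold higher number from compound 1 to compound 4 (1.15 log units; beyond the scatter), a large step. Compound 4 and the octyl side chain of compound 2 stay close, with a 2.0-fold higher number from compound 2 to compound 4 (0.30 log units; within the scatter), so these two different side chains cannot be told apart here. Nothing available explains the rise in number with ethoxycarbonyl.

From the compounds shown here alone, whether a carboxylic acid or an amine on the same saturated chain carbon would behave like compound 4 remains open. So does whether a small branched chain such as tert-butyl would match the isopropyl side chain of compound 1.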